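The source may report more compounds than this note shows. Statements on the series, on what has been measured and on what is new or still open speak of the compounds shown alone.

Three analogues built on a shared core have been tested in a functional assay on NCI-H460 cells (Homo sapiens) for inhibition, read by MTT assay, with a stated time of 72 h; on this read-out lower numbers stand for stronger inhibition and higher numbers for weaker inhibition. Compound 1 `COc1cc(NC(C)CCCNC(=O)NNC(=O)Nc2cccc(C(F)(F)F)c2)c2ncccc2c1` gives 20000 nM, compound 2 `COc1cc(NC(C)CCCNC(=O)NNC(=O)Nc2cccc(Cl)c2)c2ncccc2c1` gives 32000 nM, and compound 3 `COc1cc(NC(C)CCCNC(=O)NNC(=O)Nc2ccc(C(F)(F)F)cc2)c2ncccc2c1` gives 12000 nM. Compound 2 thus stands highest of the three, with a 2.7-fold lower number from compound 2 to compound 3 (0.43 log units; beyond the scatter) and a 1.6-fold higher number from compound 1 to compound 2 (0.20 log units; within the scatter). Compound 4 `COc1cc(NC(C)CCCNC(=O)Nc2ccc(Br)cc2)c2ncccc2c1` departs from compound 2 by 4-bromophenyl in place of ((3-chlorophenyl)carbamoyl)amino on an amide-type nitrogen. Going by the values given here, no measured step covers such a change: a 1.6-fold higher number from compound 1 to compound 2 (0.20 log units; within the scatter) and a 1.7-fold lower number from compound 1 to compound 3 (0.22 log units; within the scatter) only exchange substituents on the outer aryl ring. With no guide, the step is expected to be a 1.6-fold lower number from compound 2 to compound 4 (0.20 log units; within the scatter), not beyond the scatter in either direction. Compound 4 is therefore estimated at 20000 nM, with a wide range from 5000 nM to 80000 nM.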

Compound 4, half-maximal inhibitory concentration: 30000 nM
Beside the measured number, compound 4's estimate is 1.5-fold (0.18 log units) below it, within the range that was stated.
By their numbers in this assay, from the lowest: compounds 3, 1, 4 and 2 (each within the scatter of the next, the first and the last beyond it).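

In this assay, replacing ((3-chlorophenyl)carbamoyl)amino with 4-bromophenyl on the amide-type nitrogen gives a 1.1-fold lower number from compound 2 to compound 4 (0.03 log units; within the scatter) and so stays within the scatter. The earlier compounds shown here only exchanged substituents on the outer aryl ring, whereas this step shows that a larger change at this nitrogen, with fewer heavy atoms and no hydrogen-bond donors in the entering group, need not move the number. No evidence on hand bears on this result. The compounds shown leave open how the removal of the carbamoylamino part and the change of halogen would each act alone. They also leave open what an amine, a carboxylic acid or a longer chain at this nitrogen would give.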